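The source may report more compounds than this note shows. Statements on the series, on what has been measured and on what is new or still open speak of the compounds shown alone.

Within the data shown here, in a functional assay on the whole organism for antagonist activity, with Mus musculus as the target (a higher number here means that more compound is needed for the effect, a lower number that less compound is needed), compound 1 (`CCc1nccn1CC#CCN1CCCC1=O`) gives 2.5 mg/kg, the only true number so far. Compound 2 (`O=C1CCCN1CC#CCn1cnc2ccccc21`) gives > 100 mg/kg, which is a limit of the assay. Compound 3 (`CC(=O)N(C)C(C)C#CCn1ccnc1`) gives > 100 mg/kg, which is also a limit of the assay. The starting point for the next step is therefore a limit and not a number.

Compound 4 (`CC(=O)N(C)C(C)C#CCn1cncc1C`) comes from compound 3 by one change: methyl in place of hydrogen on an aromatic carbon. Among the measured compounds shown here, no pair of measured compounds differs in only one place, so this change has no direct precedent in this assay. The structures of compound 3 and compound 1 differ in more than one place, so compound 1 with 2.5 mg/kg is only a loose guide. A small shift towards lower doses is expected, or none beyond the scatter, and another reading at the limit is the likelier outcome. The expected step is an at least 1.2-fold lower number from compound 3 to compound 4 (0.09 log units; that floor lies within the scatter). For compound 4 the estimated dose is 80 mg/kg, with an expected range of 20 mg/kg to 200 mg/kg.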

Compound 4, dose for half-maximal effect: 3.7 mg/kg
Beside the measured number, compound 4's estimate is 22-fold (1.33 log units) above it; the whole stated range lies above it.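

In this assay, a methyl on the aromatic carbon next to the ring nitrogen and next to the ring atom that bears a large group gives an at least 27-fold lower number from compound 3 to compound 4 (1.43 log units; beyond the scatter). Among these compounds, this is the first comparison between compounds that differ in one place, and it shows that this ring position is not indifferent: one methyl in place of hydrogen is enough to turn a reading at the limit into a true number. The full size of the step stays unknown, because the value of compound 3 is a limit of the assay: the limit of > 100 mg/kg in this assay, at which 2 of the 4 values shown sit.

On these data alone, whether an isopropyl group or a chlorine on this same carbon would keep the low dose remains open. Also open, as far as these compounds go, is whether a methyl on another carbon of this ring would give a similar step.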